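The compounds below may be only part of what the source reports. "The series", "measured", "known", "first", "only" and "open" are said of these compounds alone.

For the measured compounds named here, in an ADME assay on MRC5 cells (Homo sapiens) for cytotoxicity, read by fluorescence, with a stated time of 24 h (a lower number here means a stronger inhibitor, a higher number a weaker inhibitor), compound 2 `CCC1S/C(=N\N=C\c2c(-c3ccc(Cl)cc3)[nH]c3ccccc23)NC1=O` gives 8800 nM, the only actual number so far. Compound 1 `CC1S/C(=N\N=C\c2c(-c3ccc(Br)cc3)[nH]c3ccccc23)NC1=O` gives only a limit of the assay, > 50000 nM. Compound 3 `CCC1S/C(=N\N=C\c2c(-c3ccc(Br)cc3)[nH]c3ccccc23)NC1=O` departs from compound 2 at a single place: bromo in place of chloro on an aromatic carbon, with bromo in place of chloro on an aromatic carbon. Going by the values given here, no measured step in this assay isolates this exchange, so no change beyond the scatter is expected, in either direction, from the value of compound 2 at 8800 nM. The estimated change is a 1.1-fold higher number from compound 2 to compound 3 (0.06 log units; within the scatter). For compound 3 the estimate is 10000 nM, with an expected range from 4500 nM to 30000 nM.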

Compound 3, half-maximal inhibitory concentration: 5910 nM
Estimate against measurement, compound 3: 1.7-fold (0.23 log units) above; the range from low to high includes it.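

In this assay, bromo in place of chloro on the aromatic carbon para to a large group now has a measured step (a 1.5-fold lower number from compound 2 to compound 3 (0.17 log units; within the scatter)), so the 4-chlorophenyl and 4-bromophenyl compounds read alike here. With bromo held fixed, methyl in place of hydrogen on a saturated chain carbon bound to a saturated ring carbon gives a step that does exceed the scatter (an at least 8.4-fold lower number from compound 1 to compound 3 (0.92 log units; beyond the scatter)). Compound 1 stands only at a limit of the assay, so that step is a bound and not a size: the limit of > 50000 nM in this assay, at which 1 of the 3 values shown sits.

On these data alone, what a fluoro or a methoxy group on that aromatic carbon would give stays open. So does a longer chain on the saturated ring carbon.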